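The source may report more compounds than this note shows. Statements on the series, on what has been measured and on what is new or still open speak of the compounds shown alone.

Measured compounds:
compound 1 `O[C@H](COCCOC[C@@H](O)Cc1cn(Cc2ccc(Oc3ccccc3)cc2)nn1)Cc1ccc(-c2ccccc2)cc1` 3400 nM
compound 2 `O[C@H](COCCOC[C@@H](O)Cc1cn(-c2cccs2)nn1)Cc1ccc(-c2ccccc2)cc1` 33400 nM
compound 3 `COC1=C(C)C(=O)C(CCCCCCCCCCn2cc(C[C@H](O)COCCOC[C@@H](O)Cc3ccc(-c4ccccc4)cc3)nn2)=C(C)C1=O` 4000 nM

All three were tested in a functional assay on HCT-116 cells (Homo sapiens) for inhibition, read by MTT assay, with a stated time of 72 h; on this read-out higher numbers stand for weaker inhibition of growth and lower numbers for stronger inhibition of growth. Compound 2 gives the highest of the three numbers, 33400 nM, and so the weakest growth inhibition among them. Compound 3 gives 4000 nM and compound 1 gives 3400 nM; both of these differences from compound 2 lie beyond the usual scatter, so compound 2 is clearly the least active of the three in this assay .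

Compound 4 `O[C@H](COCCOC[C@@H](O)Cc1c[nH]nn1)Cc1ccc(-c2ccccc2)cc1` has not yet been measured. It is derived from compound 2 by a single change: hydrogen in place of thiophen-2-yl on an aromatic nitrogen. Going by the values given here, no pair of measured compounds shows this exact change, so there is no direct precedent for its effect. What the three measured compounds do show is that the two compounds carrying a large group on that ring nitrogen, compound 1 and compound 3, gave lower numbers than compound 2, and compound 4 removes that nitrogen substituent altogether.

Compound 4 is therefore expected to give a number no lower than compound 2, with a step of a 1.5-fold higher number from compound 2 to compound 4 (0.18 log units; within the scatter) toward weaker inhibition estimated as likely, though its size is uncertain. The estimate for compound 4 in this assay is 50000 nM, within a range of 12000 nM to 200000 nM.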

Compound 4, concentration for 50% growth inhibition: > 100000 nM
Compound 4: a limit, no number; the forecaster's own chance of this, stated with the estimate: 25%; middle value at least 2.0-fold (0.30 log units) away from the limit.
By their numbers in this assay, from the lowest: compounds 1 and 3 (each within the scatter of the next); then compound 2. At a limit, above all of these: compound 4.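

In this assay compound 4 gives > 100000 nM, which is a limit of the assay and not a number. Hydrogen in place of thiophen-2-yl on the aromatic nitrogen gives an at least 2.9-fold higher number from compound 2 to compound 4 (0.47 log units; beyond the scatter), the only step shown that isolates a change at this position, and it shows that the thiophen-2-yl group contributes to the growth inhibition seen with compound 2, since that inhibition falls when the group is taken away. The full size of this step cannot be read, and the figure given is only its smallest possible value, as the result for compound 4 stops at a limit: the limit of > 100000 nM in this assay, at which 1 of the 4 values shown sits.

The compounds shown do not tell whether a small group such as methyl on this nitrogen would already bring back the activity of compound 2, or whether a ring such as phenyl is needed. They also give no cause for the step, so it remains unknown what the thiophen-2-yl group does in these cells that hydrogen does not.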